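From methylpiperazine to piperidine on a shared core

The source may report more compounds than this note shows. Statements on the series, on what has been measured and on what is new or still open speak of the compounds shown alone.

Among the measured compounds shown here, compound 2 `CN1CCN(Cc2ccc(NC(=O)Nc3ccc4ncnc(Nc5cccc(C(F)(F)F)c5)c4c3)cc2)CC1` gives 1650 nM in a functional assay on A549 cells (Homo sapiens) for antiproliferative activity, read by MTT assay, with a stated time of 72 h (on this read-out higher numbers stand for weaker inhibition and lower numbers for stronger inhibition), the lowest of the two numbers measured so far, and stands apart from compound 1 `C#Cc1cccc(Nc2ncnc3ccc(NC(=O)Nc4ccc(CN5CCN(C)CC5)cc4)cc23)c1`, which in this assay gives 5170 nM; that step, a 3.1-fold lower number from compound 1 to compound 2 (0.50 log units; beyond the scatter), lies beyond the scatter. Compound 3 `O=C(Nc1ccc(CN2CCCCC2)cc1)Nc1ccc2ncnc(Nc3cccc(C(F)(F)F)c3)c2c1` differs from compound 2 at a different spot: piperidin-1-yl in place of 4-methylpiperazin-1-yl on a saturated chain carbon bound to an aromatic carbon. For the measured compounds named here, the only measured step swaps a group on an aromatic carbon, not the ring on the saturated chain carbon, so no measured step bears directly on the change from compound 2 to compound 3, and its size can only be guessed. For compound 3 the expected step of a 1.5-fold higher number from compound 2 to compound 3 (0.18 log units; within the scatter) is therefore none beyond the scatter, with wide uncertainty. Compound 3 is thus expected to give about 2500 nM in this assay, with a likely range from 700 nM to 9000 nM.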

Compound 3, half-maximal inhibitory concentration: 1050 nM
Compound 3: middle estimate off by 2.4-fold (0.38 log units), on the high side; the range from low to high includes it.
By their numbers in this assay, from the lowest: compounds 3 and 2 (each within the scatter of the next); then compound 1.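

In this assay, among the compounds shown here, the first measured change on this saturated chain carbon bound to an aromatic carbon gives a 1.6-fold lower number from compound 2 to compound 3 (0.20 log units; within the scatter) and so leaves the two compounds indistinguishable on this read-out. Putting piperidin-1-yl in place of 4-methylpiperazin-1-yl takes away one ring hetero atom and one hydrogen-bond acceptor, yet no difference beyond the scatter appears. The earlier swap of ethynyl for trifluoromethyl on an aromatic carbon, by contrast, gave a 3.1-fold lower number from compound 1 to compound 2 (0.50 log units; beyond the scatter) and did go beyond the scatter. No measurement at hand explains why the ring swap leaves the result within the scatter. Still open, from the compounds shown here alone, is whether a morpholine ring or an open-chain dimethylamino group on the same carbon would also stay within the scatter. Also open, going by these compounds, is whether the piperidin-1-yl swap would read the same with ethynyl on the aromatic carbon.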